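This account rests on a few compounds, and the source may have more. Where it says the series, first, only, none or still open, it means among the compounds named here.

Going by the values given here, compound 2 `COC(=O)C#CC(O/C=C/C(=O)OC)C(C)(C)C` holds the highest of the two numbers so far in a functional assay on HBL-100 cells (Homo sapiens) for antiproliferative activity, read by sulforhodamine B assay, with a stated time of 48 h; on this read-out higher numbers stand for weaker inhibition of growth and lower numbers for stronger inhibition of growth: compound 2 gives 1800 nM, while compound 1 `CCCCC(C#CC(=O)OC)O/C=C/C(=O)OC` gives 250 nM. Among the compounds with values here, the only step measured is a 7.2-fold higher number from compound 1 to compound 2 (0.86 log units; beyond the scatter). Compound 3 `COC(=O)C#CC(O/C=C/C(=O)OC)C(C)C` differs from compound 2 by hydrogen in place of methyl on a saturated chain carbon bound to three saturated chain carbons. Because that change undoes part of the branching added in a 7.2-fold higher number from compound 1 to compound 2 (0.86 log units; beyond the scatter), a lower number is expected for compound 3, though smaller than that earlier step. The step expected is a 2.6-fold lower number from compound 2 to compound 3 (0.41 log units; beyond the scatter). Compound 3 is therefore estimated at 700 nM, with a likely range from 300 nM to 1800 nM.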

Compound 3, concentration for 50% growth inhibition: 450 nM
Compound 3: middle estimate off by 1.6-fold (0.19 log units), on the high side, within the range that was stated.
By their numbers in this assay, from the lowest: compounds 1 and 3 (each within the scatter of the next); then compound 2.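

In this assay the change from tert-butyl to isopropyl gives a 4.0-fold lower number from compound 2 to compound 3 (0.60 log units; beyond the scatter) and so takes back most of the rise seen with tert-butyl. Isopropyl and butyl, with a 1.8-fold higher number from compound 1 to compound 3 (0.26 log units; within the scatter) on this pair, cannot be told apart on this read-out. Among these three compounds, then, only tert-butyl stands apart at this place, with weaker inhibition of growth. Nothing measured here accounts for this difference. Still open, going by these compounds, is whether a methyl, a longer chain or a cyclohexyl group on this carbon would keep the number or shift it.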